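Removing a Trifluoromethyl Group: What Binding to Expect

The compounds below may be only part of what the source reports. "The series", "measured", "known", "first", "only" and "open" are said of these compounds alone.

Three compounds have been measured in an assay on cells for displacement of a labelled ligand from adenosine receptor A2b (Homo sapiens), read by scintillation counting and radioligand binding, with a stated time of 30 min, tested at 10 uM; a lower number here means less inhibition, a higher number more inhibition at the concentration tested (going by the name of the read-out):
Compound 1, `Cn1cnc2c(N3CCCCC3)nc(-c3cccc(O)c3O)nc21`, gives 26%.
Compound 2, `CN1CCN(c2nc(-c3ccc(Cl)c(C(F)(F)F)c3)nc3[nH]cnc23)CC1`, gives 25.1%.
Compound 3, `Cn1cnc2c(N3CCCCC3)nc(-c3cccc(O)c3)nc21`, gives 29.3%.

Compound 2 has the lowest of the three numbers, yet its gaps to compound 1 and to compound 3 both lie within the usual scatter, so the three cannot be told apart. Among the measured compounds shown here, the one measured step that swaps a group for hydrogen on an aromatic carbon is a number 3.3 percentage points higher from compound 1 to compound 3 (within the scatter), which stayed within the scatter. Compound 4, `CN1CCN(c2nc(-c3ccc(Cl)cc3)nc3[nH]cnc23)CC1`, differs from compound 2 by hydrogen in place of trifluoromethyl on an aromatic carbon. Because a number 3.3 percentage points higher from compound 1 to compound 3 (within the scatter) showed no shift beyond the scatter, no shift beyond the scatter is expected here either. For compound 4 the expected step is a number 2.1 percentage points lower from compound 2 to compound 4 (within the scatter). The estimate for compound 4 in this assay is 23%, in the range 8% to 40%.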

Compound 4, a percentage reported as inhibition, at one concentration (the size of the read-out at that concentration, not a potency): 6.2%
The estimate for compound 4 lay 16.8 percentage points above the measured number; the measured number lies below the stated range.
By their numbers in this assay, from the lowest: compound 4; then compounds 2, 1 and 3 (each within the scatter of the next).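

Swapping trifluoromethyl for hydrogen ortho to a chloro group is the only change shown that moves the number beyond the scatter in this assay (a number 18.9 percentage points lower from compound 2 to compound 4 (beyond the scatter)). So this place on the ring matters to the read-out, whereas the hydroxy swap on the other core (a number 3.3 percentage points higher from compound 1 to compound 3 (within the scatter)) did not register. Nothing at hand says why the number falls.

Still open, from the compounds shown here alone, is whether the drop is specific to trifluoromethyl or would appear with other groups at this place. A methyl, a methoxy or a nitrile there would help to separate the two.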